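A few compounds are considered here, and "the series" means these few. Any claim that something is new, unique, unknown or untested is made for them only; others in the source may bear on it.

Three compounds have numbers in a functional assay on HT-1080 cells (Homo sapiens), read by transwell migration, with a stated time of 24 h, tested at 1 uM; on this read-out lower numbers stand for a stronger effect and higher numbers for a weaker effect at the one concentration tested. Going by the values given here, compound 1 `O=C(Oc1cccc(Cl)c1)c1cc2cc([N+](=O)[O-])ccc2oc1=O` gives 65.8%, compound 2 `O=C(Oc1cccc(Cl)c1)c1cc2cc(CCl)ccc2oc1=O` gives 79.8%, and the one change between them, a number 14 percentage points higher from compound 1 to compound 2 (beyond the scatter), concerns the substituent on the other ring of the shared core. Compound 3 `NCc1ccc2oc(=O)c(C(=O)Oc3ccccc3)cc2c1` gives 85.5%; its number is not separated from that of compound 2 beyond the scatter, whereas against compound 1 the gap lies beyond it.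

Compound 4 `NCc1ccc2oc(=O)c(C(=O)Oc3cccc(Cl)c3)cc2c1` differs from compound 3 by chloro in place of hydrogen on an aromatic carbon, on an aromatic carbon of a six-membered aromatic ring of carbon only, meta to a large group. Among the compounds with values here, no measured step bears directly on this change: compounds 1 and 2 carry the chloro on that ring, but each also differs from compound 3 at a second place, so nothing isolates the chloro alone. Within the data shown here, the one measured step, from compound 1 to compound 2, concerns a different ring and is modest. In this assay the step of a number 3.5 percentage points lower from compound 3 to compound 4 (within the scatter) is therefore expected to stay within the scatter. Compound 4 is estimated at 82%, with a range from 68% to 96%.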

Compound 4, a percentage reported as activity, at one concentration (the size of the read-out at that concentration, not a potency): 86.6%
For compound 4 the middle estimate is 4.6 percentage points below the measured one, within the range that was stated.
By their numbers in this assay, from the lowest: compound 1; then compounds 2, 3 and 4 (each within the scatter of the next).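

In this assay, going by these compounds alone, the change from phenyl to 3-chlorophenyl gives the first isolated reading of the chloro at this place, with the aminomethyl group held constant: a number 1.1 percentage points higher from compound 3 to compound 4 (within the scatter). Within the data shown here, with that chloro retained, the other two single changes separate: amino in place of chloro on the saturated chain carbon gives a number 6.8 percentage points higher from compound 2 to compound 4 (within the scatter), while aminomethyl in place of nitro gives a number 20.8 percentage points higher from compound 1 to compound 4 (beyond the scatter), leaving the nitro-bearing compound 1 as the only one set apart from compound 4. Nothing available explains either the lack of separation at the chloro position or the gap from the nitro compound.

Still open, on these data alone, is whether the chloro step reads the same with nitro or chloromethyl on the other ring of the shared core. Also open, as far as these compounds go, is how a methoxy group or a carboxylic acid at this place would read, or a longer aminoalkyl chain in place of aminomethyl.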